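Aryloxyacetic acid amides: lipophilicity notes on a tert-butyl analogue

This account rests on a few compounds, and the source may have more. Where it says the series, first, only, none or still open, it means among the compounds named here.

Among the compounds with values here, compound 1 `O=C(O)COc1ccc(NC(=O)COc2ccccc2)cc1F` carries the only number: in a physicochemical assay for lipophilicity, using the shake flask method, at pH 7.4 (a lower number here means a more polar compound, a higher number a more lipophilic compound), compound 1 gives -1.25. Compound 2 `Cc1ccc(OCC(=O)Nc2ccc(OCC(=O)O)c(F)c2)cc1` is reported in this assay as "not determined" (no result reported), so no comparison between the two measured entries is possible. Compound 3 `CC(C)(C)c1cccc(OCC(=O)Nc2ccc(OCC(=O)O)c(F)c2)c1` differs from compound 1 by tert-butyl in place of hydrogen on an aromatic carbon. Within the data shown here, no step between measured compounds is available, so the size of the change rests on expectation alone. The step of a number 1.65 log units higher from compound 1 to compound 3 (beyond the scatter) is expected to be large and upward, well beyond the scatter. Compound 3 is accordingly estimated at 0.4, within -0.3 to 1.1.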

Compound 3, distribution coefficient: 0.35
Beside the measured number, compound 3's estimate is 0.05 log units above it; the range from low to high includes it.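

In this assay, tert-butyl in place of hydrogen on an aromatic carbon gives a number 1.60 log units higher from compound 1 to compound 3 (beyond the scatter), a large step. The series thus gains its first measured comparison at this position, on a six-membered aromatic ring of carbon only and meta to a large group, where the earlier entries offered a single number. No available evidence bears on the reason for this step. Still open, on these data alone, is how a methoxy group or an amine on the same carbon would compare. Also open, as far as these compounds go, is whether tert-butyl on another carbon of that ring would give a step of similar size.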